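From Isopropyl to Hydroxy on the Amide Chain

The source may hold more compounds than are shown below. What is called first, only, known or untested is meant among the compounds shown, and "the series" means these compounds.

In a physicochemical assay for solubility (a lower number here means a less soluble compound, a higher number a more soluble compound), compound 1 (`CCNC(=O)c1cc(C(=O)NC)c(=O)n(Cc2ccccc2)c1`) gives >= 144 ug/mL as its result, which is a limit of the assay and not a number. Within the data shown here, compound 2 (`CNC(=O)c1cc(C(=O)NCCC(C)C)cn(Cc2ccccc2)c1=O`) gives 10 ug/mL as the only true number so far. Among the measured compounds shown here, the one measured step, an at least 14-fold lower number from compound 1 to compound 2 (1.15 log units; beyond the scatter), adds isopropyl at the same place and lies beyond the scatter. Compound 3 (`CNC(=O)c1cc(C(=O)NCCO)cn(Cc2ccccc2)c1=O`) has hydroxy in place of that isopropyl (hydroxy in place of isopropyl on a saturated chain carbon, two bonds along the chain from an amide-type nitrogen). With isopropyl gone, a large rise in this assay is expected from that step alone, estimated as a 15-fold higher number from compound 2 to compound 3 (1.18 log units; beyond the scatter) overall. For compound 3 the expected value is 150 ug/mL, with an estimated range of 50 ug/mL to 400 ug/mL here.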

Compound 3, solubility: >= 140 ug/mL
Compound 3 ended at the assay's limit; the forecaster's own chance of this, stated with the estimate: 55%; the middle value lies beyond the limit too.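

Hydroxy in place of isopropyl on this saturated chain carbon gives an at least 14-fold higher number from compound 2 to compound 3 (1.14 log units; beyond the scatter) in this assay, so the low number of compound 2 is tied to what sits at this place. Compound 3 gives >= 140 ug/mL, which is a limit of the assay and not a number, so the real rise may be larger. The step from compound 1 to compound 3 cannot be read, as both results are limits.

From the compounds shown here alone, what an amine or a carboxylic acid would give at this place remains open, as does the result for a longer chain carrying the hydroxy.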